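A few compounds are considered here, and "the series" means these few. Any claim that something is new, unique, unknown or untested is made for them only; others in the source may bear on it.

Measured in a functional assay on SK-OV-3 cells (Homo sapiens) for inhibition, read by CCK-8 assay, with a stated time of 70 h; on this read-out higher numbers stand for weaker inhibition and lower numbers for stronger inhibition:
- compound 1 `O=C(O)c1cccc(COc2ccc(OCCOCCNC3CCCC3)cc2)c1`: > 100000 nM (a limit)
- compound 2 `Clc1ccc(COc2ccc(OCCOCCNC3CCCC3)cc2)cc1`: 7670 nM
- compound 3 `Nc1ccccc1COc1ccc(OCCOCCNC2CCCC2)cc1`: 14000 nM

Compound 1 gives only a limit, > 100000 nM, as noted in the limit of > 100000 nM in this assay, at which 1 of the 3 values shown sits. Compound 3, at 14000 nM, stands level with compound 2 at 7670 nM, since a 1.8-fold higher number from compound 2 to compound 3 (0.26 log units; within the scatter) is within the scatter.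

Compound 4 `Nc1cccc(COc2ccc(OCCOCCNC3CCCC3)cc2)c1` carries 3-aminophenyl in place of 2-aminophenyl on a saturated chain carbon bound to an oxygen on an aromatic ring. Going by the values given here, no measured step covers this change directly. The large steps, an at least 13-fold lower number from compound 1 to compound 2 (1.11 log units; beyond the scatter) and an at least 7.1-fold lower number from compound 1 to compound 3 (0.85 log units; beyond the scatter), both start from the 3-carboxyphenyl of compound 1 and remove that group. Among the compounds with values here, the one exchange between the two groups without it, a 1.8-fold higher number from compound 2 to compound 3 (0.26 log units; within the scatter), stays within the scatter. A change that keeps the aminophenyl group is therefore expected to give no step beyond the scatter in this assay. The expected result is a 1.2-fold lower number from compound 3 to compound 4 (0.07 log units; within the scatter). Compound 4 is estimated at 12000 nM, with an expected range of 5000 nM to 30000 nM.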

Compound 4, half-maximal inhibitory concentration: 10800 nM
Beside the measured number, compound 4's estimate is 1.1-fold (0.05 log units) above it; the range from low to high includes it.
By their numbers in this assay, from the lowest: compounds 2, 4 and 3 (each within the scatter of the next). At a limit, above all of these: compound 1.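

In this assay, taking 3-aminophenyl in place of 2-aminophenyl on a saturated chain carbon bound to an oxygen on an aromatic ring leaves the result level, with a 1.3-fold lower number from compound 3 to compound 4 (0.11 log units; within the scatter), and compound 4 also stands level with the 4-chlorophenyl group, with a 1.4-fold higher number from compound 2 to compound 4 (0.15 log units; within the scatter). Going by these compounds alone, compound 4 also provides a comparison in which only one group on an aromatic carbon is exchanged, amino in place of carboxy, and this gives an at least 9.2-fold lower number from compound 1 to compound 4 (0.96 log units; beyond the scatter), so the gap to compound 1 persists without any other change to the aromatic ring. Compound 1 still stands only as a limit: the limit of > 100000 nM in this assay, at which 1 of the 4 values shown sits.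

On these data alone, it remains open whether 4-aminophenyl or 3-chlorophenyl would stay level with compounds 2, 3 and 4. Also open, as far as these compounds go, is whether a methyl ester or a primary amide in place of the carboxy group would read like compound 4 or like compound 1.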